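The compounds below may be only part of what the source reports. "The series", "measured", "known", "first", "only" and "open" are said of these compounds alone.

Series notes. Compound 1 `O=S(=O)(CC1=NCCS1)C1C(c2ccccc2)=NN(c2ccccc2)C1c1ccccc1` is reported in a functional assay, read by Griess assay, with a stated time of 150 min, tested at 100 ug/mL (a higher number here means a stronger effect of the compound at the concentration tested, a lower number a weaker effect), as "not active" (no number reported). Compound 2 `Cc1ccc(C2CNN=C2S(=O)(=O)CC2=NCCS2)cc1` in this assay gives 52.2%. Compound 3 `O=S(=O)(CC1=NCCO1)C1=NNCC1c1ccccc1` in this assay is reported as "not active" (no number reported), so compound 3 carries no number in this assay, and no numbered step to or from compound 3 exists among the measured compounds. Compound 4 `Cc1ccc(C2CNN=C2S(=O)(=O)CC2=NCCO2)cc1` is yet to be measured. Its difference from compound 3 is methyl in place of hydrogen on an aromatic carbon. With compound 3 holding no number, the size of the step in this assay cannot be anchored; a gain of activity is expected, and the direction and size of that expectation rest only on compound 2 and the value 52.2%. Compound 4 is accordingly estimated at 30%, in a range from 0% to 60%.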

Compound 4, a percentage reported as activity, at one concentration (the size of the read-out at that concentration, not a potency): 51.4%
The estimate for compound 4 lay 21.4 percentage points below the measured number; measured number inside the range.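

In this assay, the oxygen-containing five-membered ring in place of the sulfur-containing one, on the saturated chain carbon bound to the sulfonyl sulfur, gives a number 0.8 percentage points lower from compound 2 to compound 4 (within the scatter), so with 4-methylphenyl present the two rings cannot be told apart. Compound 3 is reported as "not active" (no number reported) and compound 4 gives 51.4%, so the change from phenyl to 4-methylphenyl separates an entry without a number from a numbered one, but the step cannot be read as a size. No evidence bearing on this result is available.

On these data alone, whether methoxy or an amine in place of the methyl would keep the reading remains open. So does the reading of the sulfur-ring partner of compound 3, which carries phenyl.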